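The source may report more compounds than this note shows. Statements on the series, on what has been measured and on what is new or still open speak of the compounds shown alone.

Of the compounds shown here, three have been measured in a functional assay on HEK293 cells with D(4) dopamine receptor (Homo sapiens) as the target, read by FLIPR; a higher number here means a larger maximal response, a lower number a smaller maximal response. Compound 1 `O/N=C(\CCN1CCN(c2ccccn2)CC1)c1ccccc1` gives 70%. Compound 2 `O/N=C(\CCN1CCN(c2ccccn2)CC1)c1ccccc1Cl` gives 74%, and compound 3 `O/N=C(\CCN1CCN(c2ccccn2)CC1)c1cccc(Cl)c1` gives 73%. The step of a number 4 percentage points higher from compound 1 to compound 2 (within the scatter) and the step of a number 3 percentage points higher from compound 1 to compound 3 (within the scatter) both show that placing chloro in place of hydrogen on an aromatic carbon left the maximal response essentially unchanged, and the step of a number 1 percentage points lower from compound 2 to compound 3 (within the scatter) shows that 3-chlorophenyl in place of 2-chlorophenyl did no more. Compound 3 thus stands in a narrow band with the other two: its value lies within the scatter of both compound 1 and compound 2, so no order among the three can be claimed.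

Compound 4 `Cc1cccc(/C(CCN2CCN(c3ccccn3)CC2)=N/O)c1` is the next compound. Its change from compound 3 is methyl in place of chloro on an aromatic carbon. Going by the values given here, none of the measured steps exchanges one group for another on the same aromatic carbon, so the guidance is indirect: every change so far to this part of the structure has stayed within the scatter, and methyl in place of chloro is expected to behave alike. The step of a number 1 percentage points lower from compound 3 to compound 4 (within the scatter) is therefore expected to stay within the scatter. Compound 4 is estimated to give 72% in this assay, with a range from 62% to 82%.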

Compound 4, largest response reached (reported as efficacy), in percent of the reference or control that the assay uses: 74%
Compound 4: the middle estimate sits 2 percentage points below what was measured; low and high end bracket the measured number.
By their numbers in this assay, from the lowest: compounds 1, 3, 2 and 4 (each within the scatter of the next).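

Replacing one group with another on this aromatic carbon, meta to a large group, gives a number 1 percentage points higher from compound 3 to compound 4 (within the scatter) in this assay and so adds a direct exchange to the earlier additions of chloro to the unsubstituted phenyl ring. Methyl in place of hydrogen gives a number 4 percentage points higher from compound 1 to compound 4 (within the scatter) and extends the picture beyond chloro, while 3-methylphenyl in place of 2-chlorophenyl gives no change at the digits printed from compound 2 to compound 4 (within the scatter) even though both the group and its place on the ring differ. Across these four compounds, this read-out therefore does not separate chloro from methyl or either of them from hydrogen, and no measurement shown explains why the maximal response stays within this narrow band.

Chloro and methyl each bring a single heavy atom, so it remains open whether a larger or different group on this carbon, such as an amine, a carboxylic acid or a longer chain, would move the maximal response beyond the scatter. The compounds also leave open whether methyl on another carbon of the phenyl ring would behave as it does in 3-methylphenyl.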